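Trifluoromethyl to nitro: the next step in the series

A few compounds are considered here, and "the series" means these few. Any claim that something is new, unique, unknown or untested is made for them only; others in the source may bear on it.

Compound 1 `CCC(=O)N(c1ccc(F)cc1)C1CCCC1N(C)C`: > 50 mg/kg (a limit of the assay)
Compound 2 `CCC(=O)N(c1ccc(C(F)(F)F)cc1)C1CCCC1N(C)C`: 10 mg/kg

Among the measured compounds shown here, in a functional assay on the whole organism for positive allosteric modulation, with Mus musculus as the target (a lower number here means that less compound is needed, a higher number that more compound is needed for the effect), compound 2 gives 10 mg/kg, the only true number so far. The result for compound 1 is a limit, > 50 mg/kg.

Compound 3 `CCC(=O)N(c1ccc([N+](=O)[O-])cc1)C1CCCC1N(C)C` has nitro in place of trifluoromethyl on an aromatic carbon. For the measured compounds named here, one measured step bears on this place, an at least 5.0-fold lower number from compound 1 to compound 2 (0.69 log units; beyond the scatter), with trifluoromethyl in place of fluoro. Going by the values given here, it shows that the group here can move the number, but no measured step involves nitro. The expected step is therefore small and uncertain, a 1.5-fold higher number from compound 2 to compound 3 (0.18 log units; within the scatter), which stays within the scatter, although the wide range allows a larger move either way. For compound 3 the estimated value is 15 mg/kg, with an expected range of 5 mg/kg to 45 mg/kg.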

Compound 3, dose for half-maximal effect: 20 mg/kg
Beside the measured number, compound 3's estimate is 1.3-fold (0.12 log units) below it, and the stated range covers the measured number.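

In this assay the change to nitro gives a 2.0-fold higher number from compound 2 to compound 3 (0.30 log units; within the scatter) and so sets no order between the two groups at this place, on an aromatic carbon para to a large group. The change from fluoro gives an at least 2.5-fold lower number from compound 1 to compound 3 (0.39 log units; beyond the scatter) and so makes nitro the second group, after trifluoromethyl, to stand clear of fluoro here. Compound 1 is a limit, and the steps from it therefore have no full size: the limit of > 50 mg/kg in this assay, at which 1 of the 3 values shown sits.

The three groups shown leave open what an amine or a carboxylic acid would do at this place. Also open, from the compounds shown here alone, is whether the similar numbers for trifluoromethyl and nitro would hold with a longer chain on the carbonyl of the shared core.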